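The source may report more compounds than this note shows. Statements on the series, on what has been measured and on what is new or still open speak of the compounds shown alone.

Working notes on the series. Compound 1 (`COc1ccc(/C=C\c2cc(OC)c(OC)c(OC)c2)cc1OCc1ccc(CN2CCCCC2C(=O)NCCNC(=O)OC(C)(C)C)cc1`) and compound 2 (`COc1ccc(/C=C\c2cc(OC)c(OC)c(OC)c2)cc1OCc1ccc(CNCCNC(C)=O)cc1`) share one core. In a functional assay on B16-F10 cells (Mus musculus) for antiproliferative activity, read by CCK-8 assay, with a stated time of 48 h (on this read-out lower numbers stand for stronger inhibition and higher numbers for weaker inhibition), compound 1 gives 4700 nM and compound 2 gives 2500 nM. These two values lie within the usual scatter of each other, so compound 2 stands level with compound 1 and no order can be read from the pair.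

Compound 3 (`COc1ccc(/C=C\c2cc(OC)c(OC)c(OC)c2)cc1OCc1ccc(CN2CCCCC2C(=O)NCCN)cc1`) has not yet been measured. Compared with compound 2, it carries 2-((2-aminoethyl)carbamoyl)piperidin-1-yl in place of (2-acetamidoethyl)amino on a saturated chain carbon bound to an aromatic carbon.

Compound 1 also carries a six-membered non-aromatic ring with 1 hetero atom, and its 4700 nM remains within the scatter of the value of compound 2. On that basis, no step beyond the scatter is expected in this assay, and no firm direction can be expected either. The expected step is a 1.2-fold higher number from compound 2 to compound 3 (0.08 log units; within the scatter). For compound 3 the estimated value is 3000 nM, with an expected range of 900 nM to 10000 nM.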

Compound 3, half-maximal inhibitory concentration: 4600 nM
Compound 3: the middle estimate sits 1.5-fold (0.19 log units) below what was measured; the measured number falls inside the stated range.
By their numbers in this assay, from the lowest: compounds 2, 3 and 1 (each within the scatter of the next).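

In this assay the replacement of (2-acetamidoethyl)amino by 2-((2-aminoethyl)carbamoyl)piperidin-1-yl on a saturated chain carbon bound to an aromatic carbon gives a 1.8-fold higher number from compound 2 to compound 3 (0.26 log units; within the scatter) and so shows that this larger group, with its six-membered non-aromatic ring, can stand at this position without a step beyond the scatter. The earlier pair could not show a second point, which concerns the amine nitrogen at the end of this group: hydrogen in place of tert-butoxycarbonyl gives a 1.0-fold lower number from compound 1 to compound 3 (0.01 log units; within the scatter) and leaves compound 1 and compound 3 level in this assay with or without that capping group. The data at hand offer no explanation for either result.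

Going by these compounds, it remains open whether an acetyl group, a carboxylic acid or a longer chain in place of the terminal amine of compound 3 would give a step beyond the scatter. Also open, on these data alone, is whether a pyrrolidine ring or a morpholine ring in place of the six-membered ring of compound 3 would leave the number level with that of compound 3.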